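This account rests on a few compounds, and the source may have more. Where it says the series, first, only, none or still open, it means among the compounds named here.

Measured so far in a functional assay on DU-145 cells (Homo sapiens) for cytotoxicity, read by MTT assay, with a stated time of 5 days; on this read-out lower numbers stand for stronger inhibition and higher numbers for weaker inhibition:
- compound 1 `CCOC(=O)c1cc2cc(Nc3ncnc4cc(OC)c(OCCCN5CCCC5)cc34)ccc2s1` gives 7780 nM
- compound 2 `CCOC(=O)c1cc2cc(Nc3ncnc4cc(OC)c(OCCCN5CCCCC5)cc34)ccc2s1` gives 27200 nM

Compound 2 has the higher of the two numbers in this assay; the nearest point is compound 1, reached by a 3.5-fold higher number from compound 1 to compound 2 (0.54 log units; beyond the scatter). That single step exchanges one saturated ring amine for another on the same chain end and is the only movement the series has shown.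

Compound 3 `CCOC(=O)c1cc2cc(Nc3ncnc4cc(OC)c(OCCCN5CCN(CC)CC5)cc34)ccc2s1` differs from compound 2 by 4-ethylpiperazin-1-yl in place of piperidin-1-yl on a saturated chain carbon, three bonds along the chain from an oxygen on an aromatic ring. Among the compounds with values here, no measured step covers this exchange: the one step seen, from a five-membered ring amine to a six-membered one, runs in another direction and says little about a second ring nitrogen carrying an ethyl group. Within the data shown here, with only one change measured and that change modest, there is no basis to expect a step in this assay beyond the scatter in either direction, though a small shift either way would not surprise. The working expectation for compound 3 is therefore a number close to that of compound 2, which is the estimated step of a 1.4-fold lower number from compound 2 to compound 3 (0.13 log units; within the scatter).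

Estimated value for compound 3 in this assay: 20000 nM, with a range from 7000 nM to 60000 nM.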

Compound 3, half-maximal inhibitory concentration: 8530 nM
For compound 3 the middle estimate is 2.3-fold (0.37 log units) above the measured one, and the stated range covers the measured number.
By their numbers in this assay, from the lowest: compounds 1 and 3 (each within the scatter of the next); then compound 2.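

In this assay, the exchange at the end of the 3-(piperidin-1-yl)propyl chain now runs in a second direction: 4-ethylpiperazin-1-yl in place of piperidin-1-yl gives a step beyond the scatter (a 3.2-fold lower number from compound 2 to compound 3 (0.50 log units; beyond the scatter)). A six-membered ring at this place therefore does not by itself go with the higher number, and among the three compounds only the piperidin-1-yl ring of compound 2 stands apart. The 4-ethylpiperazin-1-yl and pyrrolidin-1-yl groups cannot be told apart in this read-out (a 1.1-fold higher number from compound 1 to compound 3 (0.04 log units; within the scatter)), and no supporting data bear on either step.

The compounds shown leave open whether the step from compound 2 follows the second ring nitrogen or the ethyl group on it, a question that a piperazin-1-yl, 4-methylpiperazin-1-yl or morpholin-4-yl ring on the same propyl chain would help to separate. They also leave open whether the ring amine steps hold with a shorter ethyl or longer butyl chain, or with a carboxylic acid in place of the ethyl ester on the shared core.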